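Acrylonitrile amides on lung cancer cells: a furan swap

The source may hold more compounds than are shown below. What is called first, only, known or untested is meant among the compounds shown, and "the series" means these compounds.

Compound 1 `N#C/C(=C\c1ccc(Cl)cc1)C(=O)c1ccc[nH]1` — 43000 nM
Compound 2 `COc1ccc(CNC(=O)/C(C#N)=C/c2ccco2)cc1` — 32000 nM
Compound 3 `N#C/C(=C\c1ccco1)C(=O)NCc1ccc(Cl)c(Cl)c1` — a limit, > 50000 nM

Of the compounds shown here, three have been measured in a functional assay on NCI-H460 cells (Homo sapiens) for inhibition, read by MTT assay, with a stated time of 72 h; on this read-out higher numbers stand for weaker inhibition of growth and lower numbers for stronger inhibition of growth. Compound 1 gives 43000 nM in this assay, and compound 2 gives 32000 nM. Compound 3 is reported only as a limit, > 50000 nM, which is the limit of > 50000 nM in this assay, at which 1 of the 3 values shown sits. So compound 3 stands at the weak end of what this assay can report, with no number of its own.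

Compound 4 `COc1ccc(/C=C(\C#N)C(=O)NCc2ccc(Cl)c(Cl)c2)cc1` is not yet measured. It differs from compound 3 in one place: 4-methoxyphenyl in place of furan-2-yl on a double-bonded chain carbon bound to a double-bonded chain carbon. For the measured compounds named here, no measured pair among the three compounds shows this change on its own, so the size of the step cannot be read from the data. Compound 4 is expected to stay in the weak range that all three measured compounds occupy, with a step of an at least 1.2-fold lower number from compound 3 to compound 4 (0.09 log units; that floor lies within the scatter) from its neighbour. Compound 4 is therefore estimated at 40000 nM, within a range from 15000 nM to 100000 nM, and a limit rather than a number is a real possibility.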

Compound 4, concentration for 50% growth inhibition: > 100000 nM
Compound 4: only a limit was reported (the forecaster's own chance of this, stated with the estimate: 45%); middle value at least 2.5-fold (0.39 log units) away from the limit.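

In this assay compound 3 is reported only as a limit, > 50000 nM. Compound 4 is also reported only as a limit, > 100000 nM, so no step can be read between compound 3 and compound 4. The compounds shown leave open whether 4-methoxyphenyl in place of furan-2-yl changes inhibition of growth at all.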